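Adding a methoxy to compound 2's benzoyl group

This account rests on a few compounds, and the source may have more. Where it says the series, first, only, none or still open, it means among the compounds named here.

Measured in a functional assay on HCT-116 cells (Homo sapiens) for cytotoxicity, read by sulforhodamine B assay, with a stated time of 48 h; on this read-out higher numbers stand for weaker inhibition and lower numbers for stronger inhibition:
compound 1 `COc1ccc(C(=O)Nc2n[nH]c3c2CN(C(=O)c2ccccc2)C3)cc1` gives 13600 nM
compound 2 `O=C(Nc1nn(C(=O)C2CC2)c2c1CN(C(=O)c1ccccc1)C2)c1ccccc1` gives 1240 nM

Of these two numbers, compound 2 holds the lower, at 1240 nM. Compound 1 stands higher at 13600 nM, a gap beyond the usual scatter. Compound 3 `COc1ccc(C(=O)Nc2nn(C(=O)C3CC3)c3c2CN(C(=O)c2ccccc2)C3)cc1` has not yet been measured. It differs from compound 2 by one change, methoxy in place of hydrogen on an aromatic carbon, para to a large group: methoxy in place of hydrogen on an aromatic carbon. For the measured compounds named here, no measured pair shows this change alone, so the data give no direct size for it. In this assay no step beyond the scatter is expected, and no firm direction can be assigned. The estimated size is a 1.0-fold higher number from compound 2 to compound 3 (0.02 log units; within the scatter). This expectation starts from compound 2 at 1240 nM. For compound 3 the expected value is 1300 nM, with an estimated range from 450 nM to 3800 nM.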

Compound 3, half-maximal inhibitory concentration: 5180 nM
For compound 3 the middle estimate is 4.0-fold (0.60 log units) below the measured one; measured number above the stated range.
By their numbers in this assay, from the lowest: compound 2; then compound 3; then compound 1.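

In this assay, going from phenyl to 4-methoxyphenyl on the aromatic carbon para to a large group moves the number upward (a 4.2-fold higher number from compound 2 to compound 3 (0.62 log units; beyond the scatter)), so this place does not take a methoxy without a measurable loss of activity. The cyclopropylcarbonyl in place of hydrogen on an aromatic nitrogen still lowers the number with the methoxy present (a 2.6-fold lower number from compound 1 to compound 3 (0.42 log units; beyond the scatter)), which shows that this change, too, can now be read on its own. Nothing measured here accounts for either step.

From the compounds shown here alone, it remains open whether a fluorine, a hydroxyl or an amine on the same aromatic carbon would move the number in the same direction as methoxy. Also open, going by these compounds, is whether a longer acyl chain, such as butanoyl, on that nitrogen would match cyclopropylcarbonyl.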